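The source may hold more compounds than are shown below. What is called first, only, known or untested is meant among the compounds shown, and "the series" means these compounds.

In a functional assay on DU-145 cells (Homo sapiens) for antiproliferative activity, read by sulforhodamine B assay, with a stated time of 72 h (on this read-out higher numbers stand for weaker inhibition and lower numbers for stronger inhibition), compound 1 `S=C(NNc1nncc2ccccc12)Nc1ccccc1` gives 45 nM and compound 2 `COc1ccc(NC(=S)NNc2nncc3ccccc23)cc1` gives 25 nM within the scatter of each other, while compound 3 `Fc1ccc(Nc2nncc3ccccc23)cc1` gives 4.3 nM as a clearly lower number. Compound 1 thus stands at the upper end of these numbers, level with compound 2. Compound 4 `NC(=S)NNc1nncc2ccccc12` differs from compound 1 by hydrogen in place of phenyl on an amide-type nitrogen as hydrogen in place of phenyl on an amide-type nitrogen. Within the data shown here, only one measured step bears on this: a 1.8-fold lower number from compound 1 to compound 2 (0.26 log units; within the scatter) for methoxy in place of hydrogen on an aromatic carbon, a change that keeps the phenyl. Among the measured compounds shown here, no measured compound lacks the phenyl, so the direction stays open. In this assay the expected step is a 1.3-fold higher number from compound 1 to compound 4 (0.12 log units; within the scatter) and nothing clearly beyond the scatter is expected. For compound 4 the estimate is 60 nM with an expected range from 15 nM to 240 nM in all.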

Compound 4, half-maximal inhibitory concentration: 65 nM
Estimate against measurement, compound 4: 1.1-fold (0.03 log units) below, within the range that was stated.
By their numbers in this assay, from the lowest: compound 3; then compounds 2, 1 and 4 (each within the scatter of the next, the first and the last beyond it).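

With hydrogen in place of phenyl on the amide-type nitrogen, this assay gives a 1.4-fold higher number from compound 1 to compound 4 (0.16 log units; within the scatter). The earlier step kept the phenyl, whereas this one shows that the whole phenyl can go from this position without a step beyond the scatter. No evidence bearing on this result is available. On these data alone, whether a methyl, a benzyl or a longer chain on this nitrogen would read the same remains open. So does the reading for a carbonyl in place of the thiocarbonyl.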